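From methoxy to tert-butyl on compound 1

The source may hold more compounds than are shown below. What is called first, only, known or untested is meant among the compounds shown, and "the series" means these compounds.

In a functional assay on CEM-SS cells (Homo sapiens) for cytotoxicity (on this read-out lower numbers stand for stronger inhibition and higher numbers for weaker inhibition), compound 1 `COc1ccc(Cn2c(N)nc3cc(Cl)c(Cl)cc32)cc1` gives 27000 nM. Two relatives share its core: compound 2 `Nc1nc2cc(Cl)c(Cl)cc2n1Cc1ccc(Cl)c(Cl)c1` gives 30000 nM, and compound 3 `Nc1nc2cc(Cl)c(Cl)cc2n1Cc1cccc(Cl)c1` gives 37000 nM. All three numbers lie within the usual scatter of one another, so compound 1 cannot be ranked apart from the other two, and the three together mark a single level.

The next compound, compound 4 `CC(C)(C)c1ccc(Cn2c(N)nc3cc(Cl)c(Cl)cc32)cc1`, carries tert-butyl in place of methoxy on an aromatic carbon. The group that enters is larger and has no hydrogen-bond acceptor, while the core stays the same.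

For the measured compounds named here, no measured step makes this exact exchange, so the evidence is indirect. Going by the values given here, the only measured step, hydrogen in place of chloro on an aromatic carbon, is a 1.2-fold higher number from compound 2 to compound 3 (0.09 log units; within the scatter), which stays within the scatter. The close values of compound 1 and compound 2 also show that different groups on this ring have so far left the number almost unmoved. On that limited basis, no change beyond the scatter is expected in this assay, and no direction is favoured. The expected step is a 1.1-fold lower number from compound 1 to compound 4 (0.03 log units; within the scatter). For compound 4 the estimated value is 25000 nM, with an expected range from 11000 nM to 55000 nM.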

Compound 4, half-maximal inhibitory concentration: 27000 nM
For compound 4 the middle estimate is 1.1-fold (0.03 log units) below the measured one; the range from low to high includes it.
By their numbers in this assay, from the lowest: compounds 1, 4, 2 and 3 (each within the scatter of the next).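

In this assay, for the compounds shown here, the exchange of methoxy for tert-butyl on this aromatic carbon gives no change at the digits printed from compound 1 to compound 4 (within the scatter) and so provides a direct reading of this position, which the earlier compounds could only suggest through a step made elsewhere on the ring. The group that enters has more heavy atoms than the one that leaves and no hydrogen-bond acceptor, yet the two compounds sit at the same level, so in this read-out neither the acceptor of methoxy nor its smaller size is needed to hold that level. Nothing available explains why the number stays put, and this pair alone offers no reason for it.

Going by these compounds alone, what remains open is whether any group at this position can move the number beyond the scatter, as methoxy and tert-butyl are only two examples and say little about an amine, a carboxylic acid or a longer chain placed there. Going by these compounds, it is also open whether removing the substituent altogether, leaving plain hydrogen on this carbon, would keep the value at the same level.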